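The source may report more compounds than this note shows. Statements on the series, on what has been measured and on what is new or still open speak of the compounds shown alone.

Values in a functional assay on MOLT-4 cells (Homo sapiens) (on this read-out lower numbers stand for stronger inhibition and higher numbers for weaker inhibition), so far:

compound 1 `Cc1ccc(-c2ncnc3c2ncn3C[C@@H]2C[C@H](CO)c3ccccc32)cc1` gives 1.4 ug/mL
compound 2 `CCOc1ncnc2c1ncn2C[C@@H]1C[C@H](CO)c2ccccc21` gives 24 ug/mL

Compound 2 holds the higher of these two numbers. Among the compounds with values here, the only measured step is a 17-fold higher number from compound 1 to compound 2 (1.23 log units; beyond the scatter), with ethoxy in place of 4-methylphenyl on an aromatic carbon.

Compound 3 `COc1ncnc2c1ncn2C[C@@H]1C[C@H](CO)c2ccccc21` has not yet been measured. Its difference from compound 2 is hydrogen in place of methyl on a saturated chain carbon bound to an oxygen on an aromatic ring, which is hydrogen in place of methyl on a saturated chain carbon bound to an oxygen on an aromatic ring, so ethoxy becomes methoxy.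

The measured step bears on this only indirectly. Going from compound 1 to compound 2 swaps a whole 4-methylphenyl for ethoxy, a far larger change than the one at issue here. Within the data shown here, no measured pair compares ethoxy with methoxy, so no direction can be drawn from the data. The expected result in this assay is no change beyond the scatter, and the estimate is anchored on compound 2 at 24 ug/mL. The expected step is a 1.0-fold higher number from compound 2 to compound 3 (0.02 log units; within the scatter), with neither direction favoured. Compound 3 is estimated at 25 ug/mL (expected range 10 ug/mL to 60 ug/mL).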

Compound 3, half-maximal inhibitory concentration: 24 ug/mL
Estimate against measurement, compound 3: 1.0-fold (0.02 log units) above; measured number inside the range.
By their numbers in this assay, from the lowest: compound 1; then compounds 2 and 3 (each within the scatter of the next).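

In this assay, shortening ethoxy to methoxy on this aromatic carbon gives no change at the digits printed from compound 2 to compound 3 (within the scatter), so removing the methyl at the end of the chain does not register on this read-out. Replacing 4-methylphenyl with methoxy gives a 17-fold higher number from compound 1 to compound 3 (1.23 log units; beyond the scatter), a step that reads the same at the digits printed as the earlier step with ethoxy, so the higher number is not confined to the ethoxy compound and holds for both small alkoxy groups shown at this place. No independent data accompany these values to explain either step.

The compounds shown leave open whether the lower number of compound 1, at 1.4 ug/mL, depends on the aromatic ring itself or on the methyl it carries, a question that plain phenyl at the same carbon would address. Also open, on these data alone, is how an amine or a longer chain such as butoxy would read at this carbon, since methoxy and ethoxy alone span too narrow a range to define a trend in chain length.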